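From cyclopropyl pyrazole to cyclopropyl imidazole at the carbonyl

The source may hold more compounds than are shown below. What is called first, only, known or untested is meant among the compounds shown, and "the series" means these compounds.

Of the compounds shown here, two with a shared core have been measured in a physicochemical assay for lipophilicity, measured as octanol-water partition, at pH 7.4; a higher number here means a more lipophilic compound, a lower number a more polar compound. Compound 1 `Cc1ccc2[nH]c(C(=O)N[C@H]3CN(S(=O)(=O)c4ccccc4)C[C@@H]3C(=O)N[C@H]3CCCNC3)cc2c1` gives 1.3, whereas compound 2 `O=C(N[C@H]1CN(S(=O)(=O)c2ccccc2)C[C@@H]1C(=O)N[C@H]1CCCNC1)c1cc(C2CC2)n[nH]1` gives 0.2, the lower of the two numbers. Compound 3 `O=C(N[C@H]1CN(S(=O)(=O)c2ccccc2)C[C@@H]1C(=O)N[C@H]1CCCNC1)c1cn(C2CC2)cn1` has not yet been measured. It differs from compound 2 only in the group on a carbonyl carbon whose other neighbours are an amide-type nitrogen: 1-cyclopropyl-1H-imidazol-4-yl in place of 3-cyclopropyl-1H-pyrazol-5-yl on a carbonyl carbon. The two have the same atoms, joined differently.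

For the measured compounds named here, only one measured step bears on this place, a number 1.10 log units lower from compound 1 to compound 2 (beyond the scatter). That step is large, but it removed 5-methyl-1H-indol-2-yl, a group absent from both compound 2 and compound 3, so its size is not expected to carry over. Going by the values given here, no measured pair shows the exchange of 3-cyclopropyl-1H-pyrazol-5-yl for 1-cyclopropyl-1H-imidazol-4-yl, which leaves the direction uncertain. A change beyond the scatter is therefore not expected, and the estimated step is a number 0.10 log units lower from compound 2 to compound 3 (within the scatter). For compound 3 the estimated value is 0.1, with an expected range from -0.4 to 0.6.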

Compound 3, distribution coefficient: -0.7
Compound 3: middle estimate off by 0.80 log units, on the high side; measured number outside the range, below it.
By their numbers in this assay, from the lowest: compound 3; then compound 2; then compound 1.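

In this assay this position responds to how the atoms are joined and not only to which atoms are present: exchanging 3-cyclopropyl-1H-pyrazol-5-yl for 1-cyclopropyl-1H-imidazol-4-yl on a carbonyl carbon, with the same atoms in both groups, gives a number 0.90 log units lower from compound 2 to compound 3 (beyond the scatter) as the result. The earlier step also replaced the atoms of 5-methyl-1H-indol-2-yl and so could not show this, and the span now seen at this position is a number 2.00 log units lower from compound 1 to compound 3 (beyond the scatter) in all. The leaving group has 1 hydrogen-bond donor and the entering group has 0 hydrogen-bond donors, but no separate measurement here explains the difference between compound 2 and compound 3.

The compounds leave open whether the step follows that change in hydrogen-bond donors or the arrangement of the ring itself, as no pair shown separates the two, and a methyl group in place of the hydrogen on the pyrazole ring nitrogen of compound 2 would bear on that question. They also leave open whether a methyl group in place of the cyclopropyl group of compound 3 would change the number.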